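The compounds below may be only part of what the source reports. "The series", "measured", "known", "first", "only" and "open" are said of these compounds alone.

The study begins from compound 1 `CCCc1nc(-c2ccccc2)c(CNCCCN2CCN(c3cccc(C(F)(F)F)c3)CC2)o1` and compound 2 `CCCc1nc(-c2ccccc2)c(CNCCCN2CCN(c3ccc(C)cc3)CC2)o1`, which share one core and differ only in the aryl group on an amine nitrogen in a ring. In an assay on HEK293 cells for inhibition of Voltage-dependent T-type calcium channel subunit alpha-1G (Homo sapiens), read by fluorescence, tested at 10 uM (on this read-out lower numbers stand for less inhibition and higher numbers for more inhibition at the one concentration tested (going by the name of the read-out)), compound 1 gives 51.6%, and compound 2 gives 53.9%. Compound 2 stands together with compound 1 within the scatter: the step of a number 2.3 percentage points higher from compound 1 to compound 2 (within the scatter) does not separate the two.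

Compound 3 `CCCc1nc(-c2ccccc2)c(CNCCCN2CCN(c3ccc(Cl)cc3)CC2)o1` has not yet been measured. Its change from compound 2 is chloro in place of methyl on an aromatic carbon, on an aromatic carbon of a six-membered aromatic ring of carbon only, para to a large group. Among the compounds with values here, only one measured step bears on this part of the molecule, and that step, a number 2.3 percentage points higher from compound 1 to compound 2 (within the scatter), exchanged the whole aryl group without moving the number beyond the scatter. A single-atom exchange on that same ring is therefore expected to give a step of about a number 0.9 percentage points lower from compound 2 to compound 3 (within the scatter) in this assay, with no direction beyond the scatter. Compound 3 is thus estimated at 53%, within a range of 40% to 66%.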

Compound 3, a percentage reported as inhibition, at one concentration (the size of the read-out at that concentration, not a potency): 63.3%
The estimate for compound 3 lay 10.3 percentage points below the measured number; measured number inside the range.
By their numbers in this assay, from the lowest: compounds 1, 2 and 3 (each within the scatter of the next, the first and the last beyond it).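

In this assay, chloro in place of methyl on the aromatic carbon para to a large group gives a number 9.4 percentage points higher from compound 2 to compound 3 (within the scatter), so this single-atom exchange does not separate compound 3 from compound 2. Within the data shown here, the wider comparison shows something the first pair did not: a number 11.7 percentage points higher from compound 1 to compound 3 (beyond the scatter) is a modest step, but it is the first in this set to pass the scatter, so the choice of aryl group on the ring amine nitrogen can register in this read-out, even though 4-methylphenyl and 3-(trifluoromethyl)phenyl did not separate. No measurement bears on why 4-chlorophenyl stands apart from 3-(trifluoromethyl)phenyl but not from 4-methylphenyl.

That step changes both the group and its place on the ring, so the two contributions cannot be told apart from these three compounds. On these data alone, whether a bromo, methoxy or nitrile group on the same aromatic carbon would extend the separation from compound 1 remains open, as does whether these single-concentration numbers reflect any difference in potency.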